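The source may hold more compounds than are shown below. What is called first, only, known or untested is meant among the compounds shown, and "the series" means these compounds.

Compound 1 `Clc1[nH]ccc2ncnc1-2`: 6%
Compound 2 `[N-]=[N+]=Nc1[nH]ccc2ncnc1-2`: 20%

Going by the values given here, in a functional assay (Homo sapiens) for inhibition of Nucleic Acid, tested at 100 uM (on this read-out lower numbers stand for less inhibition and higher numbers for more inhibition at the one concentration tested (going by the name of the read-out)), compound 2 stands as the higher of the two numbers, its only neighbour being compound 1, which gives 6%; that gap is a number 14 percentage points higher from compound 1 to compound 2 (beyond the scatter). Compound 3 `CSc1[nH]ccc2ncnc1-2` carries methylsulfanyl in place of azido on an aromatic carbon. Among the compounds with values here, the one measured step bears on this only by sharing the place on the core of compound 2: it compares azido with chloro, not methylsulfanyl with azido. Within the data shown here, with no step of the same kind to lean on, the expected move is small: a number 8 percentage points lower from compound 2 to compound 3 (within the scatter). Compound 3 is accordingly estimated at 12%, within a range from 0% to 30%.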

Compound 3, a percentage reported as inhibition, at one concentration (the size of the read-out at that concentration, not a potency): 4%
The estimate for compound 3 lay 8 percentage points above the measured number, and the stated range covers the measured number.
By their numbers in this assay, from the lowest: compounds 3 and 1 (each within the scatter of the next); then compound 2.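

In this assay the azido group now stands apart from two other groups at this aromatic carbon, since methylsulfanyl in its place loses the gain (a number 16 percentage points lower from compound 2 to compound 3 (beyond the scatter)). Methylsulfanyl and chloro cannot be told apart here (a number 2 percentage points lower from compound 1 to compound 3 (within the scatter)), so the higher number seen with azido is not shared by this other replacement of chloro. No available evidence explains why azido differs from the other two. As far as these compounds go, it remains open how an amine, a carboxylic acid or a longer chain at this carbon would read, and whether any group would exceed azido.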